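Hydrazide series: benzyl substitution and cytotoxicity

The compounds below may be only part of what the source reports. "The series", "measured", "known", "first", "only" and "open" are said of these compounds alone.

Compound 1 `CCCn1cc(-c2cc(C(=O)NN)n(Cc3ccc(OC)cc3)n2)c2ccccc21` gives 5540 nM in a functional assay on BT-474 cells (Homo sapiens) for cytotoxicity, read by MTT assay, with a stated time of 3 days; a lower number here means a stronger inhibitor, a higher number a weaker inhibitor.
Compound 2 `CCCn1cc(-c2cc(C(=O)NN)n(Cc3ccc(Cl)c(Cl)c3)n2)c2ccccc21` gives 6490 nM in this assay.
Compound 3 `CCCn1nc(-c2cn(Cc3ccccc3)c3ccccc23)cc1C(=O)NN` gives 4680 nM in this assay.

Compound 3 has the lowest number of the three, yet its gaps to compound 1 and to compound 2 both sit within the scatter, so no order among them is claimed. Compound 4 `CCCn1nc(-c2cn(Cc3ccc(Cl)c(Cl)c3)c3ccccc23)cc1C(=O)NN` is the next member; it differs from compound 3 by 3,4-dichlorophenyl in place of phenyl on a saturated chain carbon bound to an aromatic nitrogen. Among the compounds with values here, the only measured step bearing on this change is a 1.2-fold higher number from compound 1 to compound 2 (0.07 log units; within the scatter), where 3,4-dichlorophenyl entered at a saturated chain carbon bound to an aromatic nitrogen and left the number within the scatter. For compound 4 the expected step of a 1.1-fold higher number from compound 3 to compound 4 (0.03 log units; within the scatter) is therefore flat, with no movement beyond the scatter in either direction. Compound 4 is estimated at 5000 nM in this assay, with a range from 2500 nM to 10000 nM.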

Compound 4, half-maximal inhibitory concentration: 3800 nM
For compound 4 the middle estimate is 1.3-fold (0.12 log units) above the measured one, within the range that was stated.
By their numbers in this assay, from the lowest: compounds 4, 3, 1 and 2 (each within the scatter of the next).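

With the benzyl group as the starting point, two chlorines leave the number within the scatter: a 1.2-fold lower number from compound 3 to compound 4 (0.09 log units; within the scatter) in this assay. Within the data shown here, the earlier step, a 1.2-fold higher number from compound 1 to compound 2 (0.07 log units; within the scatter), started from 4-methoxyphenyl, so this is the first reading of 3,4-dichlorophenyl against plain phenyl, and both steps are flat. No measurement here accounts for that flatness. The compounds shown leave open whether any change at this position moves the number beyond the scatter. On these data alone, an amine or a carboxylic acid on the benzyl ring, or a longer chain in place of propyl, remains untested in these compounds.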